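A few compounds are considered here, and "the series" means these few. Any claim that something is new, unique, unknown or untested is made for them only; others in the source may bear on it.

Compound 1 `CCC/C=C/C(=O)Nc1cccc(Oc2nc(Nc3cccc(C#N)c3)nc3c2CSCC3)c1`: 7220 nM
Compound 2 `C=CC(=O)Nc1cccc(Oc2nc(Nc3ccc(OC)cc3)nc3c2CSCC3)c1`: 20900 nM

In a functional assay on HeLa cells (Homo sapiens) for antiproliferative activity, read by MTT assay, with a stated time of 72 h (on this read-out higher numbers stand for weaker inhibition and lower numbers for stronger inhibition), compound 2 has the higher of the two numbers, and compound 1 lies lower by more than the usual scatter. Compound 3 `CCC/C=C/C(=O)Nc1cccc(Oc2nc(Nc3ccc(OC)cc3)nc3c2CSCC3)c1` differs from compound 2 in one place: pent-1-en-1-yl in place of vinyl on a carbonyl carbon. Compound 1 carries the same pent-1-en-1-yl but also differs elsewhere, so that gap cannot be read as this change alone. Only a slight drift towards lower numbers, within the scatter, is expected, since compound 1 sits at 7220 nM. The expected size of the change is a 1.5-fold lower number from compound 2 to compound 3 (0.17 log units; within the scatter). For compound 3 the estimated value is 14000 nM, with a range of 6000 nM to 35000 nM.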

Compound 3, half-maximal inhibitory concentration: 12800 nM
Compound 3: middle estimate off by 1.1-fold (0.04 log units), on the high side, and the stated range covers the measured number.
By their numbers in this assay, from the lowest: compounds 1, 3 and 2 (each within the scatter of the next, the first and the last beyond it).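

In this assay the longer chain on the carbonyl carbon, pent-1-en-1-yl in place of vinyl, gives a 1.6-fold lower number from compound 2 to compound 3 (0.21 log units; within the scatter) and so leaves no clear gain or loss at this position. On the nitrogen on an aromatic ring, 4-methoxyphenyl in place of 3-cyanophenyl gives a 1.8-fold higher number from compound 1 to compound 3 (0.25 log units; within the scatter) and so is not resolved either. No measurement offered here explains either step.

Still open, as far as these compounds go, is whether a chain ending in an amine on the carbonyl carbon would shift the number beyond the scatter. The same question holds for a saturated pentyl chain there.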